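Swapping a fluorophenyl for a fluoropyridyl in two chalcone series

The compounds below may be only part of what the source reports. "The series", "measured", "known", "first", "only" and "open" are said of these compounds alone.

Measured so far:
compound 1 `COc1ccc(/C=C/C(=O)c2ccccc2-c2ccc(F)cc2)cc1`: 61 nM
compound 2 `COc1ccc(/C=C/C(=O)c2ccccc2-c2ccc(F)nc2)cc1`: 330 nM
compound 3 `O=C(/C=C/c1ccccc1-c1ccc(F)cc1)c1cccc(O)c1`: 8700 nM

In a functional assay on SW480 cells (Homo sapiens) for antiproliferative activity, read by sulforhodamine B assay, with a stated time of 48 h (a lower number here means a stronger inhibitor, a higher number a weaker inhibitor), compound 1 gives 61 nM, compound 2 gives 330 nM and compound 3 gives 8700 nM, the highest number of the three. The change from compound 1 to compound 2 is 6-fluoropyridin-3-yl in place of 4-fluorophenyl on an aromatic carbon, and it produced a 5.4-fold higher number from compound 1 to compound 2 (0.73 log units; beyond the scatter). Compound 4 `O=C(/C=C/c1ccccc1-c1ccc(F)nc1)c1cccc(O)c1` has not yet been measured; it carries the same change against compound 3, (6-fluoropyridin-3-yl in place of 4-fluorophenyl on an aromatic carbon), made at the same kind of place. The cores of compound 1 and compound 3 differ by a large part of the molecule, and that difference is not broken down here. Because compound 1 to compound 2 showed a 5.4-fold higher number from compound 1 to compound 2 (0.73 log units; beyond the scatter), a step of similar direction is expected from compound 3 to compound 4, a 4.0-fold higher number from compound 3 to compound 4 (0.60 log units; beyond the scatter), though the different core leaves this uncertain. Compound 4 is therefore estimated at 35000 nM, within 9000 nM to 120000 nM.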

Compound 4, half-maximal inhibitory concentration: 7400 nM
Beside the measured number, compound 4's estimate is 4.7-fold (0.67 log units) above it, outside the stated range (below it).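

In this assay, putting 6-fluoropyridin-3-yl in place of 4-fluorophenyl gave a 1.2-fold lower number from compound 3 to compound 4 (0.07 log units; within the scatter), so on this core the change made no clear difference. The effect of the change therefore did not carry over from one core to the other: the same change on two cores in this assay, a 5.4-fold higher number (0.73 log units; beyond the scatter) from compound 1 to compound 2 and a 1.2-fold lower number (0.07 log units; within the scatter) from compound 3 to compound 4, 6.4-fold (0.80 log units) apart, beyond the scatter of two such steps. Why the two cores respond differently is not shown, as they differ in a large part of the molecule and each offers only this one pair.

From the compounds shown here alone, it remains open which part of that difference sets the size of the step, and which of the two outcomes the same change would follow on a third core. Also open, going by these compounds, is how an amine in place of the fluorine would behave on either core.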